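Working notes: diethylamino in place of hydroxy on compound 3

A few compounds are considered here, and "the series" means these few. Any claim that something is new, unique, unknown or untested is made for them only; others in the source may bear on it.

In a functional assay on A549 cells (Homo sapiens) for cytotoxicity, read by MTT assay, with a stated time of 72 h (on this read-out lower numbers stand for stronger inhibition and higher numbers for weaker inhibition), compound 1 (`O=C(N/N=C/c1ccc(F)cc1Cl)Nc1cc2c(Nc3ccc(F)c(Cl)c3)ncnc2cc1O[C@H]1CCOC1`) gives 27200 nM and compound 2 (`COc1cc(/C=N/NC(=O)Nc2cc3c(Nc4ccc(F)c(Cl)c4)ncnc3cc2O[C@H]2CCOC2)cc(OC)c1OC`) gives 26400 nM with a 1.0-fold lower number from compound 1 to compound 2 (0.01 log units; within the scatter) between them. Compound 3 (`O=C(N/N=C/c1ccc(O)cc1O)Nc1cc2c(Nc3ccc(F)c(Cl)c3)ncnc2cc1O[C@H]1CCOC1`) gives 9360 nM as the lowest number of the three. Among the compounds with values here, it is reached through a 2.9-fold lower number from compound 1 to compound 3 (0.46 log units; beyond the scatter) and through a 2.8-fold lower number from compound 2 to compound 3 (0.45 log units; beyond the scatter) as the only measured steps beyond the scatter.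

Compound 4 (`CCN(CC)c1ccc(/C=N/NC(=O)Nc2cc3c(Nc4ccc(F)c(Cl)c4)ncnc3cc2O[C@H]2CCOC2)c(O)c1`) changes the 2,4-dihydroxyphenyl of compound 3 to 4-(diethylamino)-2-hydroxyphenyl (diethylamino in place of hydroxy on an aromatic carbon) with the new group meta to a hydroxy group. Within the data shown here, no measured step makes this exchange alone. The nearest evidence is a 2.9-fold lower number from compound 1 to compound 3 (0.46 log units; beyond the scatter) and a 2.8-fold lower number from compound 2 to compound 3 (0.45 log units; beyond the scatter) in which the end compound carries both hydroxy groups and the start compounds carry neither. Compound 4 keeps one of them, so part of that modest gain is expected to be lost in this assay. The expected move is a 2.1-fold higher number from compound 3 to compound 4 (0.33 log units; beyond the scatter) as a modest rise in the number. For compound 4 the estimate is 20000 nM with an expected range of 8000 nM to 45000 nM in this series.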

Compound 4, half-maximal inhibitory concentration: 15700 nM
Estimate against measurement, compound 4: 1.3-fold (0.11 log units) above; the measured number falls inside the stated range.
By their numbers in this assay, from the lowest: compounds 3, 4, 2 and 1 (each within the scatter of the next, the first and the last beyond it).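

In this assay, within the data shown here, this is the first direct reading at this place, the aromatic carbon meta to a hydroxy group: diethylamino in place of hydroxy (a 1.7-fold higher number from compound 3 to compound 4 (0.22 log units; within the scatter)) gives a step that cannot be told from the scatter. Compound 4 also cannot be separated from the two compounds without a hydroxy group (a 1.7-fold lower number from compound 2 to compound 4 (0.23 log units; within the scatter)) (a 1.7-fold lower number from compound 1 to compound 4 (0.24 log units; within the scatter)), although compound 3 is separated from both, so the compounds shown do not tie the gain seen with compound 3 to the hydroxy group replaced here. No measurement available here accounts for these readings.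

Open, from the compounds shown here alone, is whether the remaining hydroxy group contributes anything to the number of compound 4. Also open, going by these compounds, is how dimethylamino, a primary amine or a carboxylic acid on this same carbon would read against compound 3.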